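A few compounds are considered here, and "the series" means these few. Any claim that something is new, unique, unknown or untested is made for them only; others in the source may bear on it.

The series shares one core, seen in compound 1 `Fc1ccc(COc2ccc(-c3cc(CN4CCN(Cc5ccc(C(F)(F)F)cc5)CC4)no3)cc2)cc1` and compound 2 `COc1cccc(COc2ccc(-c3cc(CN4CCN(Cc5ccc(C(F)(F)F)cc5)CC4)no3)cc2)c1`. In a functional assay on Huh-7 cells (Homo sapiens) for antiproliferative activity, read by sulforhodamine B assay, with a stated time of 72 h (on this read-out lower numbers stand for stronger inhibition and higher numbers for weaker inhibition), compound 1 gives 2000 nM and compound 2 gives 800 nM. Within the data shown here, compound 2 holds the lowest of the two numbers measured so far, its nearest neighbour being compound 1; the step of a 2.5-fold lower number from compound 1 to compound 2 (0.40 log units; beyond the scatter) is modest but beyond the scatter.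

Compound 3 `COc1ccc(COc2ccc(-c3cc(CN4CCN(Cc5ccc(C(F)(F)F)cc5)CC4)no3)cc2)cc1` is not yet measured. It differs from compound 2 by 4-methoxyphenyl in place of 3-methoxyphenyl on a saturated chain carbon bound to an oxygen on an aromatic ring, the two having the same atoms joined differently. Among the measured compounds shown here, no measured step bears directly on this change; the only step on record, a 2.5-fold lower number from compound 1 to compound 2 (0.40 log units; beyond the scatter), alters the group at the same place and gives a sense of how large a swap there can read. A step of no more than modest size is therefore expected in this assay, in either direction, quite possibly none beyond the scatter. Compound 3 is expected to give about 1200 nM, between 500 nM and 3000 nM. The step of a 1.5-fold higher number from compound 2 to compound 3 (0.18 log units; within the scatter) is the expected change.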

Compound 3, half-maximal inhibitory concentration: 3200 nM
Compound 3: the middle estimate sits 2.7-fold (0.43 log units) below what was measured; the measured number lies above the stated range.
By their numbers in this assay, from the lowest: compound 2; then compounds 1 and 3 (each within the scatter of the next).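

In this assay, the place of the methoxy on the phenyl ring matters: 4-methoxyphenyl in place of 3-methoxyphenyl gives a 4.0-fold higher number from compound 2 to compound 3 (0.60 log units; beyond the scatter) and takes back the gain seen with compound 2. Methoxy in place of fluoro on an aromatic carbon gives a 1.6-fold higher number from compound 1 to compound 3 (0.20 log units; within the scatter) and so does not separate the two groups in this read-out; among the three compounds, only 3-methoxybenzyl stands apart. Nothing on hand accounts for the difference between the two methoxyphenyl isomers.

The compounds shown leave open whether other groups on the phenyl ring, such as a hydroxyl, an ethoxy or a primary amine, would read like 3-methoxyphenyl or like 4-methoxyphenyl. They also leave open whether the result for 3-methoxybenzyl holds when the rest of the shared core is changed.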